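Moving from 2-methylphenyl to 4-fluorobenzyl on the amide side chain

This account rests on a few compounds, and the source may have more. Where it says the series, first, only, none or still open, it means among the compounds named here.

Of the compounds shown here, two from this series have been measured so far. Compound 1 `CC1CCN(c2nc(C(F)(F)F)ccc2CNC(=O)C(c2ccc(F)cc2)c2ccc(NS(C)(=O)=O)c(F)c2)CC1` gives 3.4 nM in an assay on CHO cells for antagonist activity at transient receptor potential cation channel subfamily V member 1 (Homo sapiens), read by FLIPR (on this read-out lower numbers stand for stronger inhibition and higher numbers for weaker inhibition), and compound 2 `Cc1ccccc1C(C(=O)NCc1ccc(C(F)(F)F)nc1N1CCC(C)CC1)c1ccc(NS(C)(=O)=O)c(F)c1` gives 42.9 nM in this assay. Going by the values given here, compound 2 therefore carries the highest of the two numbers, and the single step known, a 13-fold higher number from compound 1 to compound 2 (1.10 log units; beyond the scatter), shows how much weaker it reads than compound 1.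

Compound 3 `CC1CCN(c2nc(C(F)(F)F)ccc2CNC(=O)C(Cc2ccc(F)cc2)c2ccc(NS(C)(=O)=O)c(F)c2)CC1` has not yet been tested. It differs from compound 2 in one place: 4-fluorobenzyl in place of 2-methylphenyl on a saturated chain carbon bound to an aromatic carbon and a carbonyl carbon. Part of this change retraces the measured step, since the 2-methylphenyl group that leaves is the one whose arrival in compound 2 went with a large rise in number. Among the compounds with values here, the 4-fluorobenzyl group that enters is, however, not the 4-fluorophenyl of compound 1, and no measured pair shows what the extra chain carbon does. The expectation is therefore a step downward in this assay, a 2.9-fold lower number from compound 2 to compound 3 (0.46 log units; beyond the scatter), but one that stays short of a full return to the number of compound 1. Compound 3 is estimated at 15 nM, with a range from 3 nM to 80 nM.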

Compound 3, inhibition constant: 49.3 nM
Compound 3: middle estimate off by 3.3-fold (0.52 log units), on the low side; the measured number falls inside the stated range.
By their numbers in this assay, from the lowest: compound 1; then compounds 2 and 3 (each within the scatter of the next).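

In this assay, the step from 2-methylphenyl to 4-fluorobenzyl on the saturated chain carbon gives a 1.1-fold higher number from compound 2 to compound 3 (0.06 log units; within the scatter), so these two quite different groups read alike at this position. The comparison with compound 1 gives a 15-fold higher number from compound 1 to compound 3 (1.16 log units; beyond the scatter), which shows that a fluorine-bearing aromatic ring does not by itself preserve the low number, since 4-fluorophenyl and 4-fluorobenzyl both carry one and still read far apart. Among these three compounds, then, only the 4-fluorophenyl group gives a low number at this position, and nothing shown here explains this.

The compounds shown leave open whether the fluorine of compound 1 matters at all, a question that plain phenyl or 4-chlorophenyl at the same place could address. They also leave open whether the number would stay flat with a longer chain such as 2-phenylethyl, or whether 2-fluorophenyl would read closer to compound 1 or to compound 2.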